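The compounds below may be only part of what the source reports. "The series", "measured", "known", "first", "only" and "open" are said of these compounds alone.

Measured so far in a functional assay on MDA-MB-231 cells (Homo sapiens) for cytotoxicity, read by MTT assay, with a stated time of 48 h; a lower number here means a stronger inhibitor, a higher number a weaker inhibitor:
compound 1 `Cc1ccc(NC(=O)NCCCCC(c2ccc(F)cc2)c2ccc(F)cc2)cc1`: > 20000 nM (a limit)
compound 2 `Cc1cccc(NC(=O)NCCCCC(c2ccc(F)cc2)c2ccc(F)cc2)c1`: > 20000 nM (a limit)

Compound 2 has no number, only a limit, and the same holds for compound 1: the limit of > 20000 nM in this assay, at which 2 of the 2 values shown sit. Compound 3 `O=C(NCCCCC(c1ccc(F)cc1)c1ccc(F)cc1)Nc1ccc(Cl)c(C(F)(F)F)c1` keeps the shared core and carries 4-chloro-3-(trifluoromethyl)phenyl in place of 3-methylphenyl on an amide-type nitrogen. Within the data shown here, the only measured step is a step that the two limits leave unreadable from compound 1 to compound 2, a swap of 4-methylphenyl for 3-methylphenyl, so it offers no size to carry over. A readable number for compound 3 would have to fall on the stronger side of the limit held by compound 2, > 20000 nM. The expected change is an at least 1.4-fold lower number from compound 2 to compound 3 (0.15 log units; that floor lies within the scatter), a modest and uncertain move towards stronger inhibition in this assay, and another limit remains quite possible. For compound 3 the estimated value is 14000 nM, with an expected range of 5000 nM to 30000 nM.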

Compound 3, half-maximal inhibitory concentration: 3150 nM
The estimate for compound 3 lay 4.4-fold (0.65 log units) above the measured number; the whole stated range lies above it.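

In this assay, the group on the amide-type nitrogen proves able to bring the series off its limit, which the two methylphenyl compounds could not show: the limit of > 20000 nM in this assay, at which 2 of the 3 values shown sit.

With 4-chloro-3-(trifluoromethyl)phenyl at this place, the change from 3-methylphenyl gives an at least 6.3-fold lower number from compound 2 to compound 3 (0.80 log units; beyond the scatter), and the change from 4-methylphenyl gives an at least 6.3-fold lower number from compound 1 to compound 3 (0.80 log units; beyond the scatter); both sizes are floors. The step between the two methylphenyl compounds cannot be read, so only the change to compound 3 carries a size.

The entering group adds chlorine and trifluoromethyl in a single change, and the compounds shown do not separate the two. Also open, as far as these compounds go, is how an amine or a carboxylic acid on this aromatic ring, or a longer chain in the shared core, would read in this assay.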